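The compounds below may be only part of what the source reports. "The series", "measured", "known", "first", "only" and "open" are said of these compounds alone.

Compound 1, `O=c1cc(CSC(=S)N2CCCCC2)oc2ccccc12`, in a functional assay on HeLa cells (Homo sapiens) for antiproliferative activity, read by MTT assay, with a stated time of 72 h (a higher number here means a weaker inhibitor, a lower number a stronger inhibitor), gives only a limit, > 25000 nM.
Compound 2, `O=c1cc(CSC(=S)N2CCCC2)oc2cc(Cl)ccc12`, gives in this assay a limit as well, > 40000 nM.
Compound 3, `O=c1c(Cl)c(CSC(=S)N2CCCCC2)oc2ccccc12`, gives in this assay 9800 nM.

For the measured compounds named here, compound 3 thus holds the only actual number among the three values; the other two are limits of the assay. Going by the values given here, the one measured step, an at least 2.5-fold lower number from compound 1 to compound 3 (0.40 log units; beyond the scatter), is at least modest and beyond the scatter, though its size is open because the value of compound 1 is a limit (the limit of > 25000 nM in this assay, at which 1 of the 3 values shown sits).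

Compound 4, `CC(C)N(C(=S)SCc1oc2ccccc2c(=O)c1Cl)C(C)C`, differs from compound 3 by diisopropylamino in place of piperidin-1-yl on a thiocarbonyl carbon. Among the compounds with values here, no measured step bears directly on this change: compound 2 differs from compound 1 in two places, so the amine swap alone cannot be read from the values shown. Without such evidence, a step within the scatter is expected. Compound 3 is therefore taken as the anchor. Compound 4 is expected to give 10000 nM, with a range from 4000 nM to 25000 nM. The expected step is a 1.0-fold higher number from compound 3 to compound 4 (0.01 log units; within the scatter).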

Compound 4, half-maximal inhibitory concentration: > 40000 nM
Compound 4: only a limit was reported (the forecaster's own chance of this, stated with the estimate: 20%); at least 4.0-fold (0.60 log units) between middle value and limit.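

In this assay, the amine on the thiocarbonyl carbon proves to matter on the shared core of compound 3: diisopropylamino in place of piperidin-1-yl gives an at least 4.0-fold higher number from compound 3 to compound 4 (0.61 log units; beyond the scatter). This is the first single change shown at that carbon, as compound 2 differs from compound 1 in two places, and the step is beyond the scatter. Its full size stays open, as compound 4 gives only a limit: the limit of > 40000 nM in this assay, at which 2 of the 4 values shown sit.

The compounds shown leave open whether a smaller open-chain amine such as dimethylamino, or a ring amine such as morpholine, would hold the number of compound 3 on this core. For the compounds shown here, also open is how pyrrolidin-1-yl, seen only in compound 2 on a different core, would behave in place of piperidin-1-yl in compound 3.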